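A few compounds are considered here, and "the series" means these few. Any claim that something is new, unique, unknown or untested is made for them only; others in the source may bear on it.

Within the data shown here, compound 1 `C/C(=N\OCc1ccncc1)c1ccc(Sc2cc(F)cc(C3CCOCC3)c2)cc1` is one of two compounds measured in a functional assay (blood) for inhibition, with Homo sapiens as the target; on this read-out higher numbers stand for weaker inhibition and lower numbers for stronger inhibition. In this assay compound 1 gives 300 nM, the higher of the two numbers, while compound 2 `COC1(c2csc(Sc3ccc4c(c3)CC/C4=N\O)c2)CCOCC1` gives 130 nM, a gap that exceeds the usual scatter. Compound 3 `C/C(=N\OCCF)c1ccc(Sc2cc(F)cc(C3CCOCC3)c2)cc1` has not been measured. It differs from compound 1 in one place: fluoromethyl in place of pyridin-4-yl on a saturated chain carbon bound to an oxygen. Among the measured compounds shown here, no measured pair shows what such a change does here, so the step from compound 1 to compound 3 is expected to be small, estimated as a 1.3-fold higher number from compound 1 to compound 3 (0.12 log units; within the scatter) and likely within the scatter. Compound 3 is therefore estimated at 400 nM, with a range from 130 nM to 1200 nM.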

Compound 3, half-maximal inhibitory concentration: 40 nM
Estimate against measurement, compound 3: 10-fold (1.00 log units) above, and the stated range ends above it.
By their numbers in this assay, from the lowest: compound 3; then compound 2; then compound 1.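

In this assay the change from (pyridin-4-yl)methyl to 2-fluoroethyl brings a 7.5-fold lower number from compound 1 to compound 3 (0.88 log units; beyond the scatter), a clear move towards stronger inhibition. At this place, on a saturated chain carbon bound to an oxygen, the aromatic ring of compound 1 is therefore not needed for inhibition, and a much smaller group without a ring does better. Nothing available explains this step. The compounds shown leave open whether the fluorine matters or losing the ring is enough. A plain ethyl group or a longer chain such as 3-fluoropropyl would help separate these two readings.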